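Inverting the Drawn Configuration of a Side-Chain Alcohol

This account rests on a few compounds, and the source may have more. Where it says the series, first, only, none or still open, it means among the compounds named here.

Of the compounds shown here, two have been measured in an assay on mitochondria (strain Sprague-Dawley) for inhibition of Amine oxidase [flavin-containing] B (Rattus norvegicus), read by spectrophotometry; a higher number here means a weaker inhibitor, a lower number a stronger inhibitor. Compound 1 `Cc1c(C)c2ccc(CCc3ccccc3)cc2oc1=O` gives 457 nM in this assay. Compound 2 `Cc1c(C)c2ccc(OC[C@@H](O)c3ccccc3)cc2oc1=O` gives 28.2 nM in this assay, the lower of the two numbers, and the gap to compound 1 lies beyond the usual scatter. Compound 3 `Cc1c(C)c2ccc(OC[C@H](O)c3ccccc3)cc2oc1=O` is the mirror form of compound 2: the two compounds have the same atoms and bonds and differ only in configuration as drawn: 1 of 1 stereo elements differ; a stereocentre at a saturated chain carbon is drawn S in compound 2 and R in compound 3. Among the compounds with values here, no measured pair here shows what such a change in configuration does, so its direction cannot be read from the data. The expectation is a modest shift toward a weaker inhibitor, a 2.1-fold higher number from compound 2 to compound 3 (0.33 log units; beyond the scatter). Compound 3 is therefore estimated at 60 nM, within a range from 12 nM to 350 nM.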

Compound 3, half-maximal inhibitory concentration: 302 nM
Estimate against measurement, compound 3: 5.0-fold (0.70 log units) below, within the range that was stated.
By their numbers in this assay, from the lowest: compound 2; then compounds 3 and 1 (each within the scatter of the next).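

Inverting this one side-chain carbon gives an 11-fold higher number from compound 2 to compound 3 (1.03 log units; beyond the scatter) in this assay as a large step, the first reading of what configuration does at this position. The step can be assigned to that carbon alone, because nothing else separates the pair: the fact that compounds 2 and 3 differ only in the configuration as drawn. At this position, the form drawn S is the stronger inhibitor of the two mirror forms.

As far as these compounds go, whether an amine in place of the alcohol would show a similar gap between mirror forms stays open. So does whether the gap would survive a longer chain.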